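Adding a Methyl to the Outer Phenyl Ring

A few compounds are considered here, and "the series" means these few. Any claim that something is new, unique, unknown or untested is made for them only; others in the source may bear on it.

Compound 1 `O=c1[nH]cc(S(=O)(=O)Nc2cccc(-c3cn(-c4ccccc4)nn3)c2)c(=O)[nH]1`: in a functional assay on OVCAR-3 cells (Homo sapiens) for antiproliferative activity, read by MTT assay, with a stated time of 24 h (on this read-out lower numbers stand for stronger inhibition and higher numbers for weaker inhibition), compound 1 gives > 20000 nM, which is a limit of the assay rather than a number.
Compound 2 `Cc1cccc(-n2cc(-c3cccc(NS(=O)(=O)c4c[nH]c(=O)[nH]c4=O)c3)nn2)c1`: in this assay compound 2 gives 4080 nM.
Compound 3 `O=c1[nH]cc(S(=O)(=O)Nc2ccc(-c3cn(-c4ccccc4)nn3)cc2)c(=O)[nH]1`: in this assay compound 3 gives 18000 nM.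

Compounds 1 and 2 share a core and differ by one change, (methyl in place of hydrogen on an aromatic carbon). That change made an at least 4.9-fold lower number from compound 1 to compound 2 (0.69 log units; beyond the scatter), with compound 1 sitting at the limit of > 20000 nM in this assay, at which 1 of the 3 values shown sits, so the true size of the step is not known, only its least size. Compound 3 has the same atoms as compound 1 joined differently; the difference between the two cores is not broken down here.

Compound 4 `Cc1ccccc1-n1cc(-c2ccc(NS(=O)(=O)c3c[nH]c(=O)[nH]c3=O)cc2)nn1` is not yet measured. It stands to compound 3 as compound 2 stands to compound 1, through (methyl in place of hydrogen on an aromatic carbon). This is the same kind of change, but not the same: in compound 2 the methyl sits meta to a large group, whereas in compound 4 it sits ortho to a large group. Given that the earlier step was an at least 4.9-fold lower number from compound 1 to compound 2 (0.69 log units; beyond the scatter), the added methyl is expected to lower the number of compound 3 as well, though the different place leaves the size uncertain, so a step of a 2.6-fold lower number from compound 3 to compound 4 (0.41 log units; beyond the scatter) is estimated. Compound 4 is therefore expected to give about 7000 nM in this assay, most likely between 2500 nM and 20000 nM.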

Compound 4, half-maximal inhibitory concentration: 7310 nM
Beside the measured number, compound 4's estimate is 1.0-fold (0.02 log units) below it, within the range that was stated.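

In this assay, the methyl that turns phenyl into 2-methylphenyl gives a 2.5-fold lower number from compound 3 to compound 4 (0.39 log units; beyond the scatter), so on this second core the change moves the number in the same direction as it did on the first, and the move is again larger than the usual scatter. This agreement in direction is what carries over from one core to the other, but the size of the effect cannot be compared, since one end of the earlier step is only a limit of the assay: the same change on two cores in this assay, an at least 4.9-fold lower number (0.69 log units; beyond the scatter) from compound 1 to compound 2 and a 2.5-fold lower number (0.39 log units; beyond the scatter) from compound 3 to compound 4; the limit leaves it open whether they differ. The methyl also does not sit in the same place on the two cores, so these two pairs show neither how much the place matters nor that the change would work the same way on any further core in this series.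

The compounds shown leave open whether another group on the outer phenyl ring, such as an ethyl, a methoxy, a chlorine or an amine, would lower the number as well. They also leave open how a methyl would behave if it were moved to other places on the outer ring of either core.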